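This account rests on a few compounds, and the source may have more. Where it says the series, first, only, none or still open, it means among the compounds named here.

Measured so far in a functional assay on KB cells (Homo sapiens) for inhibition; on this read-out lower numbers stand for stronger inhibition and higher numbers for weaker inhibition:
- compound 1 `CCCNc1nc2cc(Cl)c(Cl)cc2n1[C@@H]1O[C@@H](CO)[C@@H](O)[C@H]1O`: > 100000 nM
- compound 2 `CNc1nc2cc(Cl)c(Cl)cc2n1[C@@H]1O[C@H](CO)[C@@H](O)[C@H]1O`: > 100000 nM
- compound 3 `OC[C@H]1O[C@@H](n2c(S)nc3cc(Cl)c(Cl)cc32)[C@H](O)[C@@H]1O`: > 100000 nM

Each of these three values is a limit of the assay and not a measured number, (the limit of > 100000 nM in this assay, at which 3 of the 3 values shown sit). Among the compounds with values here, because all three sit at that limit, the single measured step among them, a step that the two limits leave unreadable from compound 2 to compound 3, cannot be given a size, and compound 3 cannot be placed relative to compound 1 or compound 2: the three are simply indistinguishable on this read-out, and no one of them can be called more or less potent than another.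

The next compound to be measured is compound 4 `CCCNc1nc2cc(Cl)c(Cl)cc2n1[C@@H]1O[C@H](CO)[C@@H](O)[C@H]1O`. Compared with compound 3 the change is this: propylamino in place of sulfanyl on an aromatic carbon. Within the data shown here, the only measured step that touches this position, a step that the two limits leave unreadable from compound 2 to compound 3, gives no readable size, so there is no evidence that swapping groups at this position moves the read-out off the limit. Compound 1 also carries a propylamino group and also reaches only the limit > 100000 nM. With nothing pointing toward a gain, compound 4 is expected to stay at the limit too, which means an expected step of a number no higher from compound 3 to compound 4 (the limit leaves the size open). The estimate for compound 4 is 100000 nM, with a range from 30000 nM to 300000 nM.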

Compound 4, half-maximal inhibitory concentration: > 100000 nM
Compound 4: no number, only a limit (the forecaster's own chance of this, stated with the estimate: 85%); the middle value sits exactly at the limit.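

Within the data shown here, no step from compound 1, compound 2 or compound 3 to compound 4 can be read, since both ends of each step are limits of the assay and not numbers: the limit of > 100000 nM in this assay, at which 4 of the 4 values shown sit.

The compounds shown leave open whether any change to them would give a measurable value in this assay, and whether the difference in configuration between compound 1 and compound 4 affects inhibition at all.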